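A Carbamate Swap on the Shared Core

The source may hold more compounds than are shown below. What is called first, only, known or untested is meant among the compounds shown, and "the series" means these compounds.

Compound 3 `COc1cc(-c2nn[nH]n2)ccc1Cn1ncc2ccc(NC(=O)OC3CCCC3)cc21` gives 7.7 in a functional assay (trachea) for antagonist activity, with Cavia porcellus as the target; on this read-out higher numbers stand for higher potency (the scale is a negative logarithm) and lower numbers for lower potency. Going by the values given here, that is the lowest of the three numbers measured so far: compound 1 `COc1ccc(OC)c(S(=O)(=O)NC(=O)c2ccc(Cn3ccc4ccc(NC(=O)CC5CCCC5)cc43)c(OC)c2)c1` gives 9.1, a number beyond the scatter above compound 3, and compound 2 `COC(=O)C(C(=O)c1ccc(Cn2ccc3ccc(NC(=O)CC4CCCC4)cc32)c(OC)c1)S(=O)(=O)c1ccccc1` gives 10.1, further above still. Compound 4 `CCCCOC(=O)Nc1ccc2cnn(Cc3ccc(-c4nn[nH]n4)cc3OC)c2c1` is next to be measured and differs from compound 3 in one place: butyl in place of cyclopentyl on an oxygen next to a carbonyl group. Among the compounds with values here, no measured pair shows this change, so nothing among the three compounds tells its size. With no such anchor, the step of a number 0.10 log units lower from compound 3 to compound 4 (within the scatter) is expected to be small, in either direction and likely not beyond the scatter. Compound 4 is therefore estimated at 7.6, within 7 to 8.2.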

Compound 4, negative logarithm of the antagonist equilibrium constant: 7.1
For compound 4 the middle estimate is 0.50 log units above the measured one; low and high end bracket the measured number.
By their numbers in this assay, from the lowest: compound 4; then compound 3; then compound 1; then compound 2.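

In this assay, butyl in place of cyclopentyl on an oxygen next to a carbonyl group gives a number 0.60 log units lower from compound 3 to compound 4 (beyond the scatter). This first measured pair shows that the number responds to the group at this place, and that the open butyl chain does not match the cyclopentyl ring there. Nothing shown accounts for the step. This single pair does not separate losing the ring from losing a carbon. From the compounds shown here alone, how a pentyl chain or a cyclohexyl ring on that oxygen would read remains open.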